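A few compounds are considered here, and "the series" means these few. Any claim that something is new, unique, unknown or untested is made for them only; others in the source may bear on it.

Measured so far:
- compound 1 `C#Cc1cccc(Nc2ncnc3cc(NC(=O)/C=C/c4ccccc4)sc23)c1`: 75600 nM
- compound 2 `O=C(/C=C/c1ccccc1)Nc1cc2ncnc(Nc3cc(Cl)cc(Cl)c3)c2s1`: > 100000 nM
- compound 3 `O=C(/C=C/c1ccc(O)cc1)Nc1cc2c(Nc3ccc(Cl)c(Cl)c3)ncnc2s1`: 60600 nM

All three were tested in a functional assay on MCF7 cells (Homo sapiens) for antiproliferative activity, read by MTT assay, with a stated time of 48 h; on this read-out lower numbers stand for stronger inhibition and higher numbers for weaker inhibition. Compound 1 gives 75600 nM. Compound 3 gives 60600 nM. Going by the values given here, for compound 2 the result is only a limit of the assay, > 100000 nM, and it is the one value of the three that sits at the limit of > 100000 nM in this assay, at which 1 of the 3 values shown sits. The step of an at least 1.3-fold higher number from compound 1 to compound 2 (0.12 log units; that floor lies within the scatter) is therefore itself only a floor, and that floor lies within the scatter, so on these numbers compound 2 stands no better than the weakest end of the series without a number to place it exactly.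

Compound 4 `O=C(/C=C/c1ccccc1)Nc1cc2ncnc(Nc3ccc(Cl)c(Cl)c3)c2s1` differs from compound 2 in one place: 3,4-dichlorophenyl in place of 3,5-dichlorophenyl on a nitrogen on an aromatic ring. Among the compounds with values here, no measured step bears directly on this exchange; the single measured step, from compound 1 to compound 2, concerns a different pair of groups, and the two values of compound 3 and compound 2 show that a compound carrying 3,4-dichlorophenyl gave a number where compound 2 gave only a limit. With nothing closer to lean on, compound 4 is expected to land near the other numbered values, which means a step of an at least 1.2-fold lower number from compound 2 to compound 4 (0.09 log units; that floor lies within the scatter) that cannot be claimed as beyond the scatter. Compound 4 is therefore estimated at 80000 nM, between 30000 nM and 200000 nM, with a real chance that only a limit is again reported.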

Compound 4, half-maximal inhibitory concentration: > 100000 nM
Compound 4 gave a limit, no number (the forecaster's own chance of this, stated with the estimate: 40%); at least 1.2-fold (0.09 log units) between middle value and limit.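

Exchanging 3,5-dichlorophenyl for 3,4-dichlorophenyl on a nitrogen on an aromatic ring brings no number into this assay, and the step from compound 2 to compound 4 cannot be read because both compounds rest on a limit: the limit of > 100000 nM in this assay, at which 2 of the 4 values shown sit.

Going by these compounds alone, the one readable step is an at least 1.3-fold higher number from compound 1 to compound 4 (0.12 log units; that floor lies within the scatter), so this exchange of 3-ethynylphenyl for 3,4-dichlorophenyl, like the one for 3,5-dichlorophenyl, gives no evidence of a change beyond the scatter. Compound 3 carries the same 3,4-dichlorophenyl along with a hydroxyl on its other phenyl ring and gives 60600 nM, so 3,4-dichlorophenyl alone does not yield a number here.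

A single pair, compound 3 and compound 4, cannot settle how much the hydroxyl contributes, and the limits leave compound 2 and compound 4 without any order. On these data alone, what a methoxy group or an amine in place of that hydroxyl would give also stays open, as does the result of a single chlorine or bromine on the phenyl ring on the nitrogen.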